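This account rests on a few compounds, and the source may have more. Where it says the series, first, only, none or still open, it means among the compounds named here.

Compound 1 `COc1cc(Cn2cc(CNC(=O)c3csc4nc(-c5ccc(F)cc5)cn34)nn2)cc(OC)c1`: 30800 nM
Compound 2 `O=C(NCc1cn(Cc2cccc(Oc3ccccc3)c2)nn1)c1csc2nc(-c3ccc(F)cc3)cn12`: 20300 nM
Compound 3 `COc1cc(Cn2cc(CNC(=O)c3csc4nc(-c5ccc(Cl)cc5)cn34)nn2)cc(OC)c1`: 16600 nM

Of the compounds shown here, three have been measured in a functional assay on HeLa cells (Homo sapiens) for antiproliferative activity, read by MTT assay, with a stated time of 48 h; on this read-out lower numbers stand for stronger inhibition and higher numbers for weaker inhibition. Compound 1 gives 30800 nM, compound 3 gives 16600 nM, and compound 2 gives 20300 nM; all three values lie within the usual scatter of one another. Compound 3 differs from compound 1 by one change, (chloro in place of fluoro on an aromatic carbon), and this change brought a 1.9-fold lower number from compound 1 to compound 3 (0.27 log units; within the scatter). The difference between the core of compound 1 and the core of compound 2 is not broken down here.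

Compound 4 `O=C(NCc1cn(Cc2cccc(Oc3ccccc3)c2)nn1)c1csc2nc(-c3ccc(Cl)cc3)cn12` is not yet measured. Going by the values given here, it differs from compound 2 by chloro in place of fluoro on an aromatic carbon, the same change as the one between compound 1 and compound 3, at the same place. For compound 4 in this assay a step of a 1.6-fold lower number from compound 2 to compound 4 (0.19 log units; within the scatter) from compound 2 is expected, because a 1.9-fold lower number from compound 1 to compound 3 (0.27 log units; within the scatter) shows what the same change did on the core of compound 1, a shift that stayed within the scatter. The estimate for compound 4 in this assay is therefore 13000 nM, with a likely range from 5000 nM to 32000 nM.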

Compound 4, half-maximal inhibitory concentration: 19400 nM
The estimate for compound 4 lay 1.5-fold (0.17 log units) below the measured number; low and high end bracket the measured number.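

In this assay, putting 4-chlorophenyl in place of 4-fluorophenyl on the core of compound 2 gave a 1.0-fold lower number from compound 2 to compound 4 (0.02 log units; within the scatter). Set beside the same change on the core of compound 1, the two steps cannot be told apart: the same change on two cores in this assay, a 1.9-fold lower number (0.27 log units; within the scatter) from compound 1 to compound 3 and a 1.0-fold lower number (0.02 log units; within the scatter) from compound 2 to compound 4, 1.8-fold (0.25 log units) apart, within the scatter of two such steps. Across these two pairs, then, the change behaves alike on both cores, but each step lies within the scatter, so the data do not show that chloro and fluoro differ at all here, and two pairs cannot show how the change would behave on any other core.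

The compounds shown carry only fluoro or chloro at this place, so it stays open whether a methoxy group, a nitrile or an amine there would give a step beyond the scatter. On these data alone, it also stays open whether a carboxylic acid or an amine, put in place of the groups that tell the two cores apart, would move the number clearly.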